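A few compounds are considered here, and "the series" means these few. Any claim that something is new, unique, unknown or untested is made for them only; others in the source may bear on it.

Of the compounds shown here, three built on one shared core have been measured in an assay on isolated protein for inhibition of Amine oxidase [flavin-containing] B (Homo sapiens), read by fluorescence and Amplex Red, with a stated time of 15 min (on this read-out higher numbers stand for weaker inhibition and lower numbers for stronger inhibition), and they differ only in what sits on the amine nitrogen next to the propargyl group. Compound 1 `C#CCNCc1cn(-c2cc(NC(=S)NCC)ncn2)cn1` carries hydrogen there and in this assay gives 5240 nM. Compound 2 `C#CCN(C)Cc1cn(-c2cc(NC(=S)NCC)ncn2)cn1` carries methyl and in this assay gives 1430 nM. Compound 3 `C#CCN(CCCC)Cc1cn(-c2cc(NC(=S)NCC)ncn2)cn1` carries butyl on that nitrogen. For compound 3 this assay reports only a limit, > 50000 nM, so it stands as the weakest of the three without a number of its own. The measured steps set the frame: a 3.7-fold lower number from compound 1 to compound 2 (0.56 log units; beyond the scatter), whereas an at least 9.5-fold higher number from compound 1 to compound 3 (0.97 log units; beyond the scatter) and an at least 34-fold higher number from compound 2 to compound 3 (1.54 log units; beyond the scatter), the last two being bounded by the limit of > 50000 nM in this assay, at which 1 of the 3 values shown sits.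

Compound 4 `C#CCN(CC#N)Cc1cn(-c2cc(NC(=S)NCC)ncn2)cn1` has not yet been measured. Relative to compound 3 the change is cyano in place of propyl on a saturated chain carbon bound to an amine nitrogen. The steps toward compound 3 show that a long chain on this nitrogen costs heavily, while the small methyl of compound 2 helps; cyanomethyl is closer in size to methyl than to butyl. A drop in the number is therefore expected, an at least 16-fold lower number from compound 3 to compound 4 (1.22 log units; beyond the scatter), bringing compound 4 back toward the range of compounds 1 and 2. Compound 4 is estimated at 3000 nM, within 700 nM to 20000 nM.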

Compound 4, half-maximal inhibitory concentration: > 50000 nM
Compound 4: a limit, no number; the forecaster's own chance of this, stated with the estimate: 15%; middle value at least 16-fold (1.22 log units) from the limit.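

In this assay, among the compounds shown here, the earlier compounds left open whether a group much shorter than butyl on this amine nitrogen would keep the inhibition seen with methyl, and cyanomethyl shows that shortness alone does not ensure it. Methyl changed to cyanomethyl gives an at least 34-fold higher number from compound 2 to compound 4 (1.54 log units; beyond the scatter), and hydrogen changed to cyanomethyl gives an at least 9.5-fold higher number from compound 1 to compound 4 (0.97 log units; beyond the scatter), so among the four compounds only hydrogen and methyl leave a measurable value on this nitrogen. Butyl and cyanomethyl cannot be ranked against each other, and the step between them cannot be read, because both compounds end at the same limit rather than at a number: the limit of > 50000 nM in this assay, at which 2 of the 4 values shown sit.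

The compounds shown leave open where the loss begins among simple chains, for instance whether ethyl or propyl on this nitrogen stays near methyl or already falls to the limit. They also leave open whether the nitrile matters in itself, which a comparison of cyanomethyl with ethyl, or with a hydroxyethyl group, could begin to separate.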